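The source may hold more compounds than are shown below. What is called first, only, known or untested is meant among the compounds shown, and "the series" means these compounds.

Measured so far:
Compound 1, `CC(C(=O)NCc1ccc(C(F)(F)F)cc1N1CCCC1)c1ccc(NS(C)(=O)=O)c(F)c1`, gives 2.3 nM in an assay on CHO cells for antagonist activity at transient receptor potential cation channel subfamily V member 1 (Homo sapiens), read by FLIPR; on this read-out lower numbers stand for stronger inhibition and higher numbers for weaker inhibition.
Compound 2, `CC(C(=O)NCc1ccc(C(F)(F)F)cc1N1CCC(C)(C)CC1)c1ccc(NS(C)(=O)=O)c(F)c1`, gives 1.3 nM in this assay.
Compound 3, `CC(C(=O)NCc1ccc(C(F)(F)F)cc1N1CCN(c2ccccc2)CC1)c1ccc(NS(C)(=O)=O)c(F)c1`, gives 2 nM in this assay.

These three compounds share one core and differ only in the group carried on one aromatic carbon. Compound 3 stands second highest of the three numbers, yet none of the gaps counts for anything: a 1.2-fold lower number from compound 1 to compound 3 (0.06 log units; within the scatter), a 1.5-fold higher number from compound 2 to compound 3 (0.19 log units; within the scatter) and a 1.8-fold lower number from compound 1 to compound 2 (0.25 log units; within the scatter) all lie within the scatter, so the three are indistinguishable on this read-out.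

Compound 4, `CC(C(=O)NCc1ccc(C(F)(F)F)cc1SCCCO)c1ccc(NS(C)(=O)=O)c(F)c1`, takes a further step from compound 3: (3-hydroxypropyl)sulfanyl in place of 4-phenylpiperazin-1-yl on an aromatic carbon. Going by the values given here, the three measured steps, each swapping one cyclic amine for another, bear on this change only loosely; the entering group has no ring and carries a hydrogen-bond donor, a feature none of the measured groups share. Since three quite different groups at this position left the number unchanged within scatter, the expectation for compound 4 is a step of about a 2.0-fold higher number from compound 3 to compound 4 (0.30 log units; within the scatter) in this assay, that is no clear shift, with the range widened to allow for the unfamiliar group. Compound 4 is estimated at 4 nM, between 1.2 nM and 15 nM.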

Compound 4, inhibition constant: "not active" (no number reported)
Compound 4: no number reported; no gap can be computed for the estimate.
By their numbers in this assay, from the lowest: compounds 2, 3 and 1 (each within the scatter of the next).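

Going by these compounds alone, compound 4 is reported as "not active" in this assay with no number, so no step from compound 3 to compound 4 can be read. What the compounds shown leave open is how far compound 4 really lies from compounds 1, 2 and 3, and which part of the swap matters. Nothing measured here explains this result.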